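This account rests on a few compounds, and the source may have more. Where it says the series, first, only, none or still open, it means among the compounds named here.

Measured so far in a functional assay on the whole organism (strain albino) for inhibition, with Rattus norvegicus as the target, read by paw edema, with a stated time of 1 h, at a dose of 20 mmol/kg by the intraperitoneal route; on this read-out higher numbers stand for more inhibition at the one dose given (going by the name of the read-out) and lower numbers for less inhibition: compound 1 `N#CC1=C(NCC(=O)N2CCOCC2)N(c2ccccc2)C(=O)N2CCCCC(N3CCCC3)C12` gives 43.9%; compound 2 `N#CC1=C(/N=C/c2ccccc2)N(c2ccccc2)C(=O)N2CCCCC(N3CCCC3)C12` gives 46.5%; compound 3 `N#Cc1c2n(c(=O)n(-c3ccccc3)c1=N)CCCCC2N1CCCC1` gives 84.6%.

Compound 2 stands second highest of these three: compound 1 sits a short way off, within the scatter, while compound 3 lies well beyond it. Compound 4 `N#CC1=C(N)N(c2ccccc2)C(=O)N2CCCCC(N3CCCC3)C12` arises from compound 2 by one nitrogen atom in place of a group of 8 heavy atoms (7 carbon, 1 nitrogen; one six-membered aromatic ring of carbon only), on a double-bonded ring carbon. Among the compounds with values here, only one measured step changes this same double-bonded ring carbon: a number 2.6 percentage points higher from compound 1 to compound 2 (within the scatter), where one substituent on that carbon was swapped for another without a change beyond the scatter. On that evidence a swap at this position is not expected to shift the read-out noticeably, so the step of a number 3.5 percentage points higher from compound 2 to compound 4 (within the scatter) is expected to stay within the scatter. Compound 4 is therefore estimated to give 50%, in a range from 32% to 68%.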

Compound 4, a percentage reported as inhibition, in the whole organism at one dose (the size of the read-out at that dose, not a potency): 77.9%
For compound 4 the middle estimate is 27.9 percentage points below the measured one; measured number outside the range, above it.
By their numbers in this assay, from the lowest: compounds 1 and 2 (each within the scatter of the next); then compounds 4 and 3 (each within the scatter of the next).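

Large substituents are not interchangeable with a bare amino group on this double-bonded ring carbon. Replacing the large group containing a phenyl ring with amino gives a number 31.4 percentage points higher from compound 2 to compound 4 (beyond the scatter), and removing ((morpholin-4-yl)carbonyl)methyl from the amine nitrogen gives a number 34 percentage points higher from compound 1 to compound 4 (beyond the scatter). The earlier step between the two large groups could not show this, as both gave similar numbers. Nothing shown here explains the rise.

The compounds shown leave open how much can be added to the amino group before the read-out falls. A methylamino or dimethylamino group at this carbon could settle that.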